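Maximal Response Along an Aryl Amine Series

The source may hold more compounds than are shown below. What is called first, only, known or untested is meant among the compounds shown, and "the series" means these compounds.

In a functional assay on CHO cells for agonist activity at Free fatty acid receptor 1 (Homo sapiens), read by a luciferase reporter (a lower number here means a smaller maximal response, a higher number a larger maximal response), compound 1 `O=C(O)c1ccc(NCc2cccc(Oc3ccccc3)c2)cc1` gives 86%.
In this assay compound 2 `O=C(O)[C@@H]1C[C@H]1c1ccc(NCc2cccc(Oc3ccccc3)c2)cc1` gives 64%.
In this assay compound 3 `NC(=O)CCc1ccc(NCc2cccc(Oc3ccccc3)c2)cc1` gives 68%.

Compound 3 stands second highest of the three. Its nearest neighbour is compound 2, with the step of a number 4 percentage points higher from compound 2 to compound 3 (within the scatter), and its furthest is compound 1, with the step of a number 18 percentage points lower from compound 1 to compound 3 (beyond the scatter). Compound 4 `CC(C)NC(=O)[C@H]1C[C@@H]1c1ccc(NCc2cccc(Oc3ccccc3)c2)cc1` has not yet been measured; it differs from compound 3 by 2-(isopropylcarbamoyl)cyclopropyl in place of 2-carbamoylethyl on an aromatic carbon.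

Going by the values given here, two measured steps bear on this change. Leaving carboxy for the ring gave a number 22 percentage points lower from compound 1 to compound 2 (beyond the scatter), and leaving carboxy for the open-chain amide gave a number 18 percentage points lower from compound 1 to compound 3 (beyond the scatter), so both departures from the acid lowered the response by a modest amount. Between the ring acid and the open-chain amide the step was a number 4 percentage points higher from compound 2 to compound 3 (within the scatter). Among the compounds with values here, compound 4 joins ring and amide, with an isopropyl on the amide that no measured pair covers. Because a number 4 percentage points higher from compound 2 to compound 3 (within the scatter) lay within the scatter, compound 4 is expected to show a number 6 percentage points lower from compound 3 to compound 4 (within the scatter). For compound 4 the estimate in this assay is 62%, between 45% and 78%.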

Compound 4, largest response reached (reported as percent of maximum), in percent of the reference or control that the assay uses: 62%
Compound 4: the middle estimate sits on the measured number at the digits printed, within the range that was stated.
By their numbers in this assay, from the lowest: compounds 4, 2 and 3 (each within the scatter of the next); then compound 1.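

In this assay the step of a number 6 percentage points lower from compound 3 to compound 4 (within the scatter) and the step of a number 2 percentage points lower from compound 2 to compound 4 (within the scatter) show that the 2-(isopropylcarbamoyl)cyclopropyl group, with its three-membered ring and its added isopropyl, keeps the response level with both the open-chain amide and the ring acid. The carboxy group of compound 1 stands apart, with a number 24 percentage points lower from compound 1 to compound 4 (beyond the scatter) in this comparison, so at this position, para to a large group, all three replacements shown lie beyond the scatter of compound 1 yet within the scatter of one another. No measurement at hand offers an explanation for this result.

The compounds shown leave open how the ring and the isopropyl each count alone, which a cyclopropyl bearing a plain carbamoyl group or an open chain bearing the isopropyl amide would tell. Also open, on these data alone, is whether a longer chain or an amine in this place would bring the response back toward that of compound 1.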